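The compounds below may be only part of what the source reports. "The series", "measured", "known", "first", "only" and "open" are said of these compounds alone.

Compound 1 `Cc1ccc(S(=O)(=O)Oc2c(-c3ccccc3)c(-c3ccccc3)n3ccc(C#N)cc23)cc1` gives 25000 nM.
Compound 2 `N#Cc1ccn2c(-c3ccccc3)c(-c3ccccc3)c(CO)c2c1` gives 34000 nM.

For the measured compounds named here, in an assay for inhibition of Polyunsaturated fatty acid lipoxygenase ALOX15 (Oryctolagus cuniculus) (on this read-out higher numbers stand for weaker inhibition and lower numbers for stronger inhibition), compound 2, with 34000 nM, stands at the highest of the two numbers, and the only step known is a 1.4-fold higher number from compound 1 to compound 2 (0.13 log units; within the scatter). Compound 3 `N#Cc1ccn2c(-c3ccccc3)c(-c3ccccc3)c(C(=O)c3ccccc3)c2c1` carries benzoyl in place of hydroxymethyl on an aromatic carbon. Going by the values given here, no measured step involves a benzoyl group, and the one step that touches this aromatic carbon stayed within the scatter, so little ground exists for predicting a large shift. Compound 3 is therefore expected to change by a 1.1-fold lower number from compound 2 to compound 3 (0.05 log units; within the scatter), not beyond the scatter. The estimated value of compound 3 is 30000 nM, with a range from 8000 nM to 100000 nM.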

Compound 3, half-maximal inhibitory concentration: 43000 nM
Compound 3: middle estimate off by 1.4-fold (0.16 log units), on the low side; the measured number falls inside the stated range.
By their numbers in this assay, from the lowest: compounds 1, 2 and 3 (each within the scatter of the next).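

In this assay, benzoyl on this aromatic carbon of the five-membered ring brings a six-membered aromatic ring and removes the hydrogen-bond donor of hydroxymethyl, yet the result is only a 1.3-fold higher number from compound 2 to compound 3 (0.10 log units; within the scatter). The comparison with ((4-methylphenyl)sulfonyl)oxy at the same carbon is likewise small, at a 1.7-fold higher number from compound 1 to compound 3 (0.24 log units; within the scatter), so all three groups there remain inseparable on this read-out. Nothing available accounts for this flatness. From the compounds shown here alone, whether an amine or a carboxylic acid on this carbon would move the number beyond the scatter remains open, as does the effect of changing either phenyl group.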